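The source may report more compounds than this note shows. Statements on the series, on what has been measured and on what is new or still open speak of the compounds shown alone.

Measured compounds:
- compound 2, `COc1cc2c(Oc3ccc(NC(=O)c4nnn(-c5ccccc5Cl)c4C(F)(F)F)cc3F)ccnc2cc1OCCCN1CCN(C)CC1`, in a functional assay on U-87MG ATCC cells (Homo sapiens) for cytotoxicity, read by MTT assay, with a stated time of 72 h (on this read-out lower numbers stand for stronger inhibition and higher numbers for weaker inhibition), gives 1220 nM
- compound 1, `COc1cc2c(Oc3ccc(NC(=O)c4nnn(-c5ccc(C)cc5)c4C(F)(F)F)cc3F)ccnc2cc1OCCCN1CCC(C)CC1`, in this assay gives 2800 nM

Of the two compounds measured in this assay, compound 2 gives the lower number, and its gap to compound 1 is beyond the usual scatter of this kind of measurement. Compound 3, `COc1cc2c(Oc3ccc(NC(=O)c4nnn(-c5ccc(C)cc5)c4C(F)(F)F)cc3F)ccnc2cc1OCCCN1CCN(C)CC1`, has not been measured yet. It keeps the shared core and the N-methylpiperazine-bearing side chain of compound 2, and differs from it in one place: 4-methylphenyl in place of 2-chlorophenyl on an aromatic nitrogen. Going by the values given here, no step between two measured compounds covers this exact exchange, so the expected size of the step rests on indirect evidence. Compound 1 carries the same 4-methylphenyl group that enters in compound 3, and in this assay compound 1 gives 2800 nM. On that basis the step from compound 2 to compound 3 is expected to be a modest move toward a weaker result, estimated as a 1.6-fold higher number from compound 2 to compound 3 (0.21 log units; within the scatter), though a result within the scatter of compound 2 would not be surprising. Compound 3 is therefore estimated at 2000 nM in this assay, with a likely range from 900 nM to 4500 nM.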

Compound 3, half-maximal inhibitory concentration: 2170 nM
Compound 3: middle estimate off by 1.1-fold (0.04 log units), on the low side; low and high end bracket the measured number.
By their numbers in this assay, from the lowest: compounds 2, 3 and 1 (each within the scatter of the next, the first and the last beyond it).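

In this assay, the exchange of 2-chlorophenyl for 4-methylphenyl on the aromatic nitrogen now has a direct reading: a 1.8-fold higher number from compound 2 to compound 3 (0.25 log units; within the scatter). At this position, then, this change has no effect that stands clear of the differences seen between repeated measurements. The exchange in the side chain, 4-methylpiperazin-1-yl in place of 4-methylpiperidin-1-yl, also has a direct reading, a 1.3-fold lower number from compound 1 to compound 3 (0.11 log units; within the scatter), so compound 3 connects to each of the other two compounds by a single change that cannot be told apart from scatter on its own. No measurement shown here speaks to why these steps have the size they do.

The aryl exchange alters two things at once, the kind of group on the ring and where it sits, so its two parts remain unseparated; plain phenyl, 4-chlorophenyl or 2-methylphenyl on the same nitrogen would pull them apart. Going by these compounds, it also remains open whether a larger change at this position, such as a ring carrying a carboxylic acid or an amine, would move the number beyond the scatter.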